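The source may hold more compounds than are shown below. What is called first, only, known or untested is meant among the compounds shown, and "the series" means these compounds.

Compound 2 `O=C(CCS(=O)(=O)c1cccc2ncsc12)N1CCN(c2ccnc(C(F)(F)F)c2)CC1` gives "not determined" (no result reported) in an ADME assay on microsomes from liver (Rattus norvegicus) for metabolic stability, read by LC-MS, with a stated time of 15 min, tested at 1 uM (on this read-out lower numbers stand for a less stable compound and higher numbers for a more stable compound), so there is no number on which it stands, and the other measured compounds offer the only footing. Compound 1 `Cc1cc(F)cnc1N1CCN(C(=O)CCCc2cccc3ncc(CO)cc23)[C@@H](C)C1` gives 1% in this assay. Compound 3 `Cc1cc(F)cnc1N1CCN(C(=O)CCCc2cccc3ncsc23)[C@@H](C)C1` gives 5.3% in this assay. Compound 4 `O=C(CCS(=O)(=O)c1cccc2ncsc12)N1CCN(c2ccc(C(F)(F)F)cn2)CC1` differs from compound 2 in one place: 5-(trifluoromethyl)pyridin-2-yl in place of 2-(trifluoromethyl)pyridin-4-yl on an amine nitrogen in a ring. Among the compounds with values here, with no value for compound 2, no step in this assay can be named in size or direction, and nothing more than the usual scatter can be foreseen. Compound 4 is expected to sit low in this assay, estimated at 15%, with a range from 2% to 50%.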

Compound 4, percent of the compound remaining: 41%
Beside the measured number, compound 4's estimate is 26 percentage points below it; low and high end bracket the measured number.
By their numbers in this assay, from the lowest: compounds 1 and 3 (each within the scatter of the next); then compound 4.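

Within the data shown here, compound 2 has no reported result in this assay, so no step to compound 4 at 41% can be read. What 5-(trifluoromethyl)pyridin-2-yl in place of 2-(trifluoromethyl)pyridin-4-yl does to the percent remaining stays open, and no evidence shown bears on the result.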